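The source may report more compounds than this note shows. Statements on the series, on what has been measured and on what is new or still open speak of the compounds shown alone.

Measured so far, in an in vivo ADME assay on the whole organism (strain C57BL/cAnNCrl) for metabolic stability, with Mus musculus as the target, at a dose of 10 mg/kg by the oral route; on this read-out higher numbers stand for a longer-lived compound and lower numbers for a shorter-lived compound:
- compound 1, `CC(C)(C)c1cc(NC(=O)Nc2cccc(Oc3ccnc4[nH]c(=O)cnc34)c2)n(-c2ccccc2)n1`, gives 1.4 h
- compound 2, `Cc1ccc(-n2nc(C(C)(C)C)cc2NC(=O)Nc2ccc(Oc3ccnc4[nH]c(S)nc34)cc2F)cc1`, gives 3.3 h

Compound 2 holds the higher of the two half-lives; the gap down to compound 1 lies beyond the usual scatter, so compound 2 is the longer-lived of the pair. Compound 3, `Cc1ccc(-n2nc(C(C)(C)C)cc2NC(=O)Nc2ccc(Oc3ccnc4[nH]c(=O)cnc34)cc2F)cc1`, keeps the substituted pyrazole and the fluorinated central ring of compound 2 but carries the bicyclic ether substituent of compound 1: a group of 11 heavy atoms (7 carbon, 3 nitrogen, 1 oxygen; one six-membered aromatic ring with 1 hetero atom, one six-membered aromatic ring with 2 hetero atoms) in place of a group of 10 heavy atoms (6 carbon, 3 nitrogen, 1 sulfur; one five-membered aromatic ring with 2 hetero atoms, one six-membered aromatic ring with 1 hetero atom), on an oxygen on an aromatic ring. Among the compounds with values here, no measured pair isolates this exchange, so the step can only be expected, not read off. Since compound 1, which already bears the entering group, shows the lower value of 1.4 h, compound 3 is expected to fall below compound 2, most likely by a modest step of a 1.7-fold lower number from compound 2 to compound 3 (0.22 log units; within the scatter). The estimate for compound 3 in this assay is 2 h, within a range of 1 h to 4 h.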

Compound 3, half-life: 5.9 h
For compound 3 the middle estimate is 3.0-fold (0.47 log units) below the measured one, and the stated range ends below it.
By their numbers in this assay, from the lowest: compound 1; then compounds 2 and 3 (each within the scatter of the next).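

Within the data shown here, for the first time, a single exchange on an oxygen on an aromatic ring can be read on its own in this assay: the group of 11 heavy atoms with a double bond outside aromatic rings takes the place of the sulfur-bearing group of 10 heavy atoms, with a 1.8-fold higher number from compound 2 to compound 3 (0.25 log units; within the scatter). As this step lies within the scatter, the two groups cannot be told apart at this place on half-life, and the exchange leaves no readable change on this core. Nothing at hand bears on why the half-life responds in this way.

The compounds shown leave open how a group carrying an amine or a carboxylic acid would fare on the same oxygen. They also leave open whether the same exchange would give a similar result on the core of compound 1.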